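Moving the Chloro Around the Benzylsulfanyl Ring

This account rests on a few compounds, and the source may have more. Where it says the series, first, only, none or still open, it means among the compounds named here.

Compound 1 `CC1=C(C(=O)Nc2ccc(F)cc2)C(c2ccc([N+](=O)[O-])cc2)N=C(SCc2ccccc2)N1`, compound 2 `CC1=C(C(=O)Nc2ccc(F)cc2)C(c2ccc([N+](=O)[O-])cc2)N=C(SCc2ccccc2Cl)N1` and compound 3 `CC1=C(C(=O)Nc2ccc(F)cc2)C(c2ccc([N+](=O)[O-])cc2)N=C(SCc2cccc(Cl)c2)N1` share one core and differ only in the group on a saturated chain carbon bound to a sulfur. In a functional assay on the whole organism (artery, strain albino) with Rattus norvegicus as the target, with a stated time of 60 min, at a dose of 10 mg/kg by the oral route (on this read-out lower numbers stand for less inhibition and higher numbers for more inhibition at the one dose given (going by the name of the read-out)), compound 1 gives 12.3%, compound 2 gives 6.2% and compound 3 gives 7.2%. Among these three numbers compound 3 stands second highest, nearest compound 2 and furthest from compound 1, both gaps within the scatter. Compound 4 `CC1=C(C(=O)Nc2ccc(F)cc2)C(c2ccc([N+](=O)[O-])cc2)N=C(SCc2ccc(Cl)cc2)N1` carries the change (4-chlorophenyl in place of 3-chlorophenyl on a saturated chain carbon bound to a sulfur). For the measured compounds named here, the one step of the same kind, a number 1 percentage points higher from compound 2 to compound 3 (within the scatter), stayed within the scatter, as did adding the chloro at all, a number 6.1 percentage points lower from compound 1 to compound 2 (within the scatter) and a number 5.1 percentage points lower from compound 1 to compound 3 (within the scatter). For compound 4 no step beyond the scatter is therefore expected, a number 0.8 percentage points higher from compound 3 to compound 4 (within the scatter). Compound 4 is estimated at 8%, between 2% and 16%.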

Compound 4, a percentage reported as inhibition, in the whole organism at one dose (the size of the read-out at that dose, not a potency): 11.8%
Beside the measured number, compound 4's estimate is 3.8 percentage points below it, and the stated range covers the measured number.
By their numbers in this assay, from the lowest: compounds 2, 3, 4 and 1 (each within the scatter of the next).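

Completing the set with 4-chlorophenyl on the saturated chain carbon bound to a sulfur, this assay separates none of the chloro placements: the steps read a number 4.6 percentage points higher from compound 3 to compound 4 (within the scatter) and a number 5.6 percentage points higher from compound 2 to compound 4 (within the scatter). The 4-chlorophenyl group also stays within the scatter of the ring without chloro (a number 0.5 percentage points lower from compound 1 to compound 4 (within the scatter)), so at this one dose the position of the chloro shows no readable effect. Nothing measured here bears on why. Open, from the compounds shown here alone, is whether an amine or a carboxylic acid on this ring, or a longer chain in place of the benzyl, would give a step beyond the scatter.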